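Notes on the step from compound 3 to compound 4

This account rests on a few compounds, and the source may have more. Where it says the series, first, only, none or still open, it means among the compounds named here.

Values in a functional assay on HUVEC cells (Homo sapiens) for inhibition, with a stated time of 4 days (a lower number here means a stronger inhibitor, a higher number a weaker inhibitor), so far
compound 1 `COc1ccc(C(N)=O)cc1/C=C/c1ccc(F)cc1` gives 2100 nM
compound 2 `COc1ccc(/C=C/c2cc(C(N)=O)ccc2OC)cc1` gives 8800 nM
compound 3 `CNC(=O)c1ccc(OC)c(/C=C/c2ccc(Cl)cc2)c1` gives 190 nM

Compound 3 has the lowest number of the three, and its gaps to compound 1 and compound 2 both lie beyond the scatter. Compound 4 `COc1ccc(C(=O)NCCO)cc1/C=C/c1ccc(Cl)cc1` is next, and the difference is hydroxymethyl in place of hydrogen on a saturated chain carbon bound to an amide-type nitrogen in the amide chain. In words, this is hydroxymethyl in place of hydrogen on a saturated chain carbon bound to an amide-type nitrogen, so methylcarbamoyl becomes (2-hydroxyethyl)carbamoyl.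

Among the measured compounds shown here, no measured pair varies this chain alone. For the measured compounds named here, the only measured single-place step is a 4.2-fold higher number from compound 1 to compound 2 (0.62 log units; beyond the scatter) and it concerns methoxy in place of fluoro on an aromatic carbon, so it bears on this change only as a rough guide to size. A similarly modest step is therefore expected in this assay toward a higher number, as compound 3 at 190 nM already sits lowest. The estimate is a 2.1-fold higher number from compound 3 to compound 4 (0.32 log units; beyond the scatter) in this read-out. For compound 4 the estimated value is 400 nM with an expected range of 110 nM to 1500 nM for now.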

Compound 4, half-maximal inhibitory concentration in the HUVEC assay: 910 nM
Beside the measured number, compound 4's estimate is 2.3-fold (0.36 log units) below it; the range from low to high includes it.
By their numbers in the HUVEC assay, from the lowest: compound 3; then compound 4; then compound 1; then compound 2.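

Among the compounds shown here, this is the first measured step on the amide chain: in the HUVEC assay compound 3 gives 190 nM and compound 4 gives 910 nM. In the HUVEC assay, replacing hydrogen with hydroxymethyl on a saturated chain carbon bound to an amide-type nitrogen gives a 4.8-fold higher number from compound 3 to compound 4 (0.68 log units; beyond the scatter) and so shows that this position is sensitive to the change. In a physicochemical assay for solubility, read by HPLC, in simulated intestinal fluid, with a stated time of 2 h, tested at 10 mM (on this read-out lower numbers stand for lower solubility and higher numbers for higher solubility), compound 3 gives 24 ug/mL and compound 4 gives 16 ug/mL. In the physicochemical assay, the same pair gives a 1.5-fold lower number from compound 3 to compound 4 (0.18 log units; within the scatter) and so is not separated on that read-out, and no measured evidence is available to explain either result.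

The compounds shown leave open whether the oxygen of the 2-hydroxyethyl group or the added chain carbon carries the step in the HUVEC assay, a question that an ethyl or 2-methoxyethyl group on the amide-type nitrogen would address. Also open, on these data alone, is how a 2-aminoethyl or carboxymethyl group at this nitrogen would read in the HUVEC assay and the physicochemical assay.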